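This account rests on a few compounds, and the source may have more. Where it says the series, first, only, none or still open, it means among the compounds named here.

Compound 1, `CCc1ccccc1-c1nc(N)nc(N)n1`: 1.65
Compound 2, `Cc1c(N(C)C)c(=O)n(-c2ccccc2)c(=O)n1CCO`: 0.85

The measure at hand is a physicochemical assay for lipophilicity; a lower number here means a more polar compound, a higher number a more lipophilic compound. In this assay compound 1 gives 1.65, and compound 2 gives 0.85. Of the two numbers, compound 2 stands lowest; its nearest neighbour is compound 1, whose value lies higher by a margin beyond the usual scatter of such measurements, so the two are genuinely apart. Compound 3, `Cc1c(N(C)C)c(=O)n(-c2ccccc2)c(=O)n1C`, has not yet been measured in this assay. It differs from compound 2 in one place: hydrogen in place of hydroxymethyl on a saturated chain carbon bound to an aromatic nitrogen. For the measured compounds named here, no pair of measured compounds that differ in just one place is available, so the size of this kind of step cannot be read from the data and has to be estimated from the change itself. The step expected here, a number 0.55 log units higher from compound 2 to compound 3 (beyond the scatter), is upward and of moderate size, beyond the scatter. On that basis compound 3 is expected to give about 1.4 in this assay, with a plausible range from 0.9 to 1.9.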

Compound 3, partition coefficient: 1.3
For compound 3 the middle estimate is 0.10 log units above the measured one; the measured number falls inside the stated range.
By their numbers in this assay, from the lowest: compound 2; then compound 3; then compound 1.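

In this assay, for the compounds shown here, the change from 2-hydroxyethyl to methyl, which puts hydrogen in place of hydroxymethyl on a saturated chain carbon bound to an aromatic nitrogen, gives a number 0.45 log units higher from compound 2 to compound 3 (beyond the scatter) and is the first change here that can be read on its own, with the rest of the structure held constant. Compound 1 and compound 2 differ in more than one place, so the gap between them could not be tied to any single group, whereas this number moves with the loss of one hydroxymethyl: 2 heavy atoms, 1 hydrogen-bond donor and 1 hydrogen-bond acceptor. The number at this position therefore responds to the change, but nothing on hand says which feature of the departing group accounts for the shift.

A single pair cannot show whether the number follows chain length or the hydroxyl end of the chain, and a plain ethyl or propyl chain, or a 2-methoxyethyl or 2-aminoethyl group, at this place would help separate the two. Going by these compounds, whether a step of this size would recur on a different core, such as that of compound 1, also remains open.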